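A few compounds are considered here, and "the series" means these few. Any claim that something is new, unique, unknown or untested is made for them only; others in the source may bear on it.

Measured so far:
compound 1 `CC[C@H](C)[C@H](N)CN(C(=O)[C@@H]1C[C@H]1c1ccccc1)c1ccc(-c2ccccc2)cc1` — 230 nM; 800 nM (2 entries)
compound 2 `CC[C@H](C)[C@H](N)CN(C(=O)[C@@H]1C[C@H]1c1ccccc1Cl)c1ccc(-c2ccccc2)cc1` — > 25000 nM

In a functional assay for agonist activity at G protein-coupled receptor 88 (Homo sapiens), read by HTRF and cAMP accumulation (on this read-out lower numbers stand for an effect already at smaller amounts and higher numbers for an effect only at larger amounts of compound), compound 1 gives 230 nM; 800 nM (2 entries), as seen in the several entries of compound 1 in this assay, 230 nM; 800 nM (2 entries). Compound 2 reaches only (the limit of > 25000 nM in this assay, at which 1 of the 2 values shown sits), a limit of this assay and not a number. Compound 3 `CC[C@H](C)[C@H](N)CN(C(=O)[C@@H]1C[C@H]1c1ccc(OC)cc1)c1ccc(-c2ccccc2)cc1` differs from compound 2 by 4-methoxyphenyl in place of 2-chlorophenyl on a saturated ring carbon. Among the measured compounds shown here, no measured step covers this change; the values of compound 1 and compound 2 show only that the phenyl and 2-chlorophenyl analogues lie far apart. Compound 3 is expected at 5000 nM, between 500 nM and 30000 nM. This estimate means an expected step of an at least 5.0-fold lower number from compound 2 to compound 3 (0.69 log units; beyond the scatter) toward lower numbers, though a limit remains possible.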

Compound 3, half-maximal effective concentration: > 25000 nM
Compound 3 gave a limit, no number; the forecaster's own chance of this, stated with the estimate: 40%; middle value at least 5.0-fold (0.69 log units) away from the limit.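

Compound 2 and compound 3 each gave only a limit and no number, so the step between them cannot be read. The compounds shown leave open whether 4-methoxyphenyl and 2-chlorophenyl differ in effect at all.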